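Series notes: aryloxyacetic acids, side-chain exchange

A few compounds are considered here, and "the series" means these few. Any claim that something is new, unique, unknown or untested is made for them only; others in the source may bear on it.

For the measured compounds named here, compound 1 `CCOc1cc(C)c(-c2cccc(COc3ccc(OCC(=O)O)c(F)c3)c2)c(C)c1` is the only member of this set with a number in a physicochemical assay for lipophilicity, using the shake flask method, in phosphate buffer, measured as octanol-water partition, with a stated time of 24 h, at pH 7.4, tested at 100 uM; a higher number here means a more lipophilic compound, a lower number a more polar compound; there compound 1 gives 3.48. Going by the values given here, compound 2 `Cc1cc(OCCOCc2ccccc2)cc(C)c1-c1cccc(COc2ccc(OCC(=O)O)c(F)c2)c1` carries a benzyloxy-terminated chain in place of the ethoxy group of compound 1, but in this assay compound 2 gives "not determined" (no result reported), so compound 2 stands nowhere on the measured scale and no step from compound 1 can be stated. Compound 3 `Cc1cc(OCCCS(C)(=O)=O)cc(C)c1-c1cccc(COc2ccc(OCC(=O)O)c(F)c2)c1` differs from compound 2 in one place: (methylsulfonyl)methyl in place of benzyloxy on a saturated chain carbon, two bonds along the chain from an oxygen on an aromatic ring. Among the compounds with values here, no measured step of this kind exists in the set, so the size of the change is an expectation only. The move from compound 2 to compound 3 is expected to lower the distribution coefficient, and clearly beyond the usual scatter rather than within it. Because compound 1 gives 3.48 with a shorter ethoxy chain at the same position, compound 3 is estimated at 2.5, within 1.7 to 3.3.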

Compound 3, distribution coefficient: 1.81
The estimate for compound 3 lay 0.69 log units above the measured number; low and high end bracket the measured number.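

In this assay the position carrying the ether chain now has a measured step, a number 1.67 log units lower from compound 1 to compound 3 (beyond the scatter), with (methylsulfonyl)methyl in place of hydrogen on a saturated chain carbon, two bonds along the chain from an oxygen on an aromatic ring. This shows that the distribution coefficient of the series can move by a large amount through a change at this one position alone, something a single number could not show. The step from compound 2 to compound 3 cannot be read, and no measurement at hand accounts for the size of the step from compound 1.

The compounds shown leave open how much of this step belongs to the methylsulfonyl group and how much to the longer chain that carries it. A plain propoxy chain, or an amine or a sulfonamide at the end of the same chain, would separate these contributions.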